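The source may report more compounds than this note shows. Statements on the series, on what has been measured and on what is new or still open speak of the compounds shown alone.

Working notes on a small set sharing one core. Compound 1 `Nc1ccc(-c2nc3ccc(F)cc3s2)cc1I`, compound 2 `Nc1ccc(-c2nc3ccc(F)cc3s2)cc1Cl` and compound 3 `Nc1ccc(-c2nc3cc(F)ccc3s2)cc1Cl` have been measured; compound 4 `Nc1ccc(-c2nc3cc(F)ccc3s2)cc1I` has not.

In a functional assay on MCF7 cells (Breast, Homo sapiens) for inhibition (a higher number here means a weaker inhibitor of growth, a lower number a stronger inhibitor of growth), compound 1 gives < 10 nM, which is a limit of the assay and not a number. In this assay compound 2 gives < 10 nM, again a limit. In this assay compound 3 gives < 10 nM, also a limit.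

Compound 1 differs from compound 2 by iodo in place of chloro on an aromatic carbon. The resulting step, a step that the two limits leave unreadable from compound 2 to compound 1, cannot be sized, since both ends sit at the limit of < 10 nM in this assay, at which 3 of the 3 values shown sit. How the core of compound 3 differs from that of compound 2 is not broken down here.

Compound 4 differs from compound 3 by iodo in place of chloro on an aromatic carbon, the same change as that from compound 2 to compound 1, at a place described in the same words. Compound 4 is therefore expected to give 5 nM, between 1.5 nM and 15 nM, because compounds 1, 2 and 3 all sit at the limit of < 10 nM in this assay, at which 3 of the 3 values shown sit. The expected step that the limit leaves unreadable from compound 3 to compound 4 is thus estimated as essentially flat, most likely ending again at the limit rather than at a number.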

Compound 4, concentration for 50% growth inhibition: < 10 nM
Compound 4: a limit, no number; the forecaster's own chance of this, stated with the estimate: 80%; the middle value does not contradict the limit.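

In this assay compound 4 gives < 10 nM which is a limit of the assay and not a number. Among these compounds, compound 3 also stands at a limit, so no step from compound 3 to compound 4 can be read. The compounds shown leave open how far compound 1, compound 2, compound 3 and compound 4 differ in growth inhibition: the limit of < 10 nM in this assay, at which 4 of the 4 values shown sit.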